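The source may hold more compounds than are shown below. What is called first, only, known or untested is meant among the compounds shown, and "the series" means these compounds.

Compound 2, `COCCn1nc(C(=O)N[C@H]2COc3ccccc3N(C)C2=S)nc1Cc1ccccc1`, is tested in a toxicity assay on HT-29 cells (Homo sapiens) for cytotoxicity; a lower number here means that less compound is tolerated, a higher number that more compound is tolerated. In this assay compound 2 gives > 100000 nM, which is a limit of the assay and not a number. Two close relatives share its core and differ from it only in the group on the aromatic nitrogen. Compound 1, `CC(C)n1nc(C(=O)N[C@H]2COc3ccccc3N(C)C2=S)nc1Cc1ccccc1`, carries an isopropyl there, and in this assay compound 1 gives > 100000 nM, again a limit. Compound 3, `CN1C(=S)[C@@H](NC(=O)c2nc(Cc3ccccc3)n(C3CCCCCC3)n2)COc2ccccc21`, carries a cycloheptyl, and in this assay compound 3 gives > 100000 nM, also a limit. The step that the two limits leave unreadable from compound 1 to compound 2, the step that the two limits leave unreadable from compound 2 to compound 3 and the step that the two limits leave unreadable from compound 1 to compound 3 therefore cannot be read, because of the limit of > 100000 nM in this assay, at which 3 of the 3 values shown sit.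

Compound 4, `CN1C(=S)[C@@H](NC(=O)c2nc(Cc3ccccc3)n(CC3CCOCC3)n2)COc2ccccc21`, has not yet been measured. It differs from compound 2 in one place: oxan-4-yl in place of methoxymethyl on a saturated chain carbon bound to an aromatic nitrogen. The measured steps bear on this change only in that three different groups on the aromatic nitrogen all leave the compound at the limit, so no step beyond the usual scatter is expected here either. The step that the limit leaves unreadable from compound 2 to compound 4 is expected to be small. Compound 4 is expected to give 150000 nM in this assay, with a range from 50000 nM to 500000 nM, and most probably to be reported once more only as a limit.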

Compound 4, half-maximal cytotoxic concentration: > 100000 nM
Compound 4: only a limit was reported (the forecaster's own chance of this, stated with the estimate: 85%); the middle value does not contradict the limit.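

No step from compound 1, compound 2 or compound 3 to compound 4 can be read, because compound 4 also gives only a limit, not a number, as the other three do: the limit of > 100000 nM in this assay, at which 4 of the 4 values shown sit.

The compounds shown leave open at what concentration each of them would become toxic in this assay, and so whether the group on the aromatic nitrogen matters there.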